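Replacing 3-fluorophenyl with ethyl on the amide carbonyl

This account rests on a few compounds, and the source may have more. Where it says the series, first, only, none or still open, it means among the compounds named here.

Measured in a physicochemical assay for solubility, read by LC-MS, in phosphate buffer, with a stated time of 24 h, at pH 6.8; a lower number here means a less soluble compound, a higher number a more soluble compound:
Compound 1 `C[C@H](NC(=O)c1cccc(F)c1)c1ccc(NC(=O)N2CC(c3cccnc3)C2)cc1`: 11000 nM
Compound 2 `C[C@H](NC(=O)[C@@H]1CCCN1C)c1ccc(NC(=O)N2CC(c3cccnc3)C2)cc1`: > 1000000 nM (a limit)
Compound 3 `C[C@H](NC(=O)c1cccc(F)c1)c1ccc(NC(=O)N2CC(c3ccc(N)nc3)C2)cc1`: 32000 nM

Compound 3 has the higher of the two exact numbers. The gap between them is a 2.9-fold higher number from compound 1 to compound 3 (0.46 log units; beyond the scatter). For compound 2, this assay gives only a limit, (the limit of > 1000000 nM in this assay, at which 1 of the 3 values shown sits).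

Compound 4 `CCC(=O)N[C@@H](C)c1ccc(NC(=O)N2CC(c3ccc(N)nc3)C2)cc1` keeps the rest of compound 3 but carries ethyl in place of 3-fluorophenyl on a carbonyl carbon. One measured step changes this same place: an at least 90-fold higher number from compound 1 to compound 2 (1.95 log units; beyond the scatter). This step is large, but it brings in 1-methylpyrrolidin-2-yl rather than ethyl, so it points to a direction more firmly than to a size. The other measured step, a 2.9-fold higher number from compound 1 to compound 3 (0.46 log units; beyond the scatter), is modest and concerns amino in place of hydrogen on an aromatic carbon, a feature that compound 4 retains from compound 3. A rise beyond the scatter in this assay is therefore expected, though a smaller one than the step to compound 2. The expected change is a 6.3-fold higher number from compound 3 to compound 4 (0.80 log units; beyond the scatter). The estimated value for compound 4 is 200000 nM, with an expected range from 70000 nM to 600000 nM.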

Compound 4, solubility: 760000 nM
Beside the measured number, compound 4's estimate is 3.8-fold (0.58 log units) below it; measured number above the stated range.
By their numbers in this assay, from the lowest: compound 1; then compound 3; then compound 4. At a limit, above all of these: compound 2.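

At this place, on a carbonyl carbon whose other neighbour is an amide-type nitrogen, replacing 3-fluorophenyl now has a size that can be read from two exact numbers in this assay: a 24-fold higher number from compound 3 to compound 4 (1.38 log units; beyond the scatter). The entering ethyl has no ring, no hydrogen-bond donors or acceptors and no net charge, so a large step at this place is seen without the 1-methylpyrrolidin-2-yl of compound 2, and it is large where the step at the aromatic carbon, a 2.9-fold higher number from compound 1 to compound 3 (0.46 log units; beyond the scatter), is modest. Compound 2 remains a limit and gives no exact size for the earlier change at this place: the limit of > 1000000 nM in this assay, at which 1 of the 4 values shown sits.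

The compounds shown leave open whether a longer chain such as butyl would stay close to ethyl or fall back toward 3-fluorophenyl at this place, and how an amine or a carboxylic acid on such a chain would compare. Ethyl is also seen here only with the amino group retained from compound 3, so the size of its step without that amino group remains unknown.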